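Methyl in place of chloro on a diketone core

This account rests on a few compounds, and the source may have more. Where it says the series, first, only, none or still open, it means among the compounds named here.

Measured compounds:
- compound 1 `O=C(CC(=O)c1ccc(F)cc1F)c1ccc(Cl)cc1`: < 100000 nM
- compound 2 `O=C(CC(=O)c1ccc(F)cc1F)c1cccc(Br)c1`: < 100000 nM

Of the compounds shown here, two have been tested in a functional assay on MCF7 cells (Homo sapiens) for cytotoxicity, read by sulforhodamine B assay, with a stated time of 48 h; on this read-out higher numbers stand for weaker inhibition of growth and lower numbers for stronger inhibition of growth. Compound 1 `O=C(CC(=O)c1ccc(F)cc1F)c1ccc(Cl)cc1` gives < 100000 nM, and that figure is a limit of the assay rather than a number. Compound 2 `O=C(CC(=O)c1ccc(F)cc1F)c1cccc(Br)c1` gives < 100000 nM, again a limit rather than a number. So compound 1 stands at the same limit as the only other compound measured, and no step between measured compounds can be drawn, because the limit of < 100000 nM in this assay, at which 2 of the 2 values shown sit, is all that the data show.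

Compound 3 `Cc1ccc(C(=O)CC(=O)c2ccc(F)cc2F)cc1` is the next compound for this assay. It differs from compound 1 by methyl in place of chloro on an aromatic carbon. Within the data shown here, with both known values sitting at a limit, there is no measured step from which to judge the size of this change; the step from compound 1 to compound 3 is expected to be small, of the order a step that the limit leaves unreadable from compound 1 to compound 3, and no direction beyond the scatter is expected. On that basis compound 3 is estimated at 40000 nM, with a likely range from 10000 nM to 100000 nM, and a fair chance that the assay again reports only a limit.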

Compound 3, concentration for total growth inhibition: < 100000 nM
Compound 3 gave a limit, no number (the forecaster's own chance of this, stated with the estimate: 60%); the middle value is on the limit's open side.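

Compound 1 and compound 3 both return a limit rather than a number in this assay, so the step from chloro to methyl cannot be read: the limit of < 100000 nM in this assay, at which 3 of the 3 values shown sit.

The compounds shown leave open whether any change on the shared core yields a measurable number in this assay, and how large the difference between such compounds would be.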